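Pyridyl ether in place of the terminal carbamate

The source may hold more compounds than are shown below. What is called first, only, known or untested is meant among the compounds shown, and "the series" means these compounds.

Compound 3 `CCNC(=O)OC[C@H](C1CC1)n1cc(Cl)nc(Nc2cc(C)c(OC)nc2C)c1=O` gives 14 nM in an assay on frontal cortex for displacement of a labelled ligand from corticotropin-releasing factor receptor 1 (Rattus norvegicus), with a stated time of 2 h (a lower number here means a stronger inhibitor, a higher number a weaker inhibitor), the highest of the three numbers; compound 2 `COc1ccc(NC(=O)OC[C@H](C2CC2)n2cc(Cl)nc(Nc3cc(C)c(OC)nc3C)c2=O)c(C)n1` gives 9.2 nM and compound 1 `COc1nc(C)c(Nc2nc(Cl)cn([C@H](COC(=O)c3ccccc3)C3CC3)c2=O)cc1C` gives 1.5 nM, so a 1.5-fold higher number from compound 2 to compound 3 (0.18 log units; within the scatter) while a 9.3-fold higher number from compound 1 to compound 3 (0.97 log units; beyond the scatter) and a 6.1-fold higher number from compound 1 to compound 2 (0.79 log units; beyond the scatter). Compound 4 `COc1nc(C)c(Nc2nc(Cl)cn([C@H](COc3cccnc3)C3CC3)c2=O)cc1C` carries pyridin-3-yl in place of ethylcarbamoyl on an oxygen on a saturated carbon. Among the measured compounds shown here, no measured step exchanges the whole carbamate for an aryl ether, so the bearing of the earlier steps is indirect: they show that an aromatic ring at this end, as in compound 1 with 1.5 nM, goes with a lower number than either carbamate, and that swapping between carbamate substituents hardly matters. An ether lacks the carbonyl shared by all three measured compounds, which adds uncertainty. A modest move toward lower numbers is expected, a 3.1-fold lower number from compound 3 to compound 4 (0.49 log units; beyond the scatter), short of the step seen to compound 1. Compound 4 is estimated at 4.5 nM, with a range from 1.5 nM to 14 nM.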

Compound 4, half-maximal inhibitory concentration: 6.7 nM
Estimate against measurement, compound 4: 1.5-fold (0.17 log units) below; the range from low to high includes it.
By their numbers in this assay, from the lowest: compound 1; then compounds 4, 2 and 3 (each within the scatter of the next, the first and the last beyond it).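

Loss of the carbonyl is tolerated at this position: with pyridin-3-yl on the oxygen in place of ethylcarbamoyl, the series shows a 2.1-fold lower number from compound 3 to compound 4 (0.32 log units; beyond the scatter). Against the aryl carbamate, the same ether gives a 1.4-fold lower number from compound 2 to compound 4 (0.14 log units; within the scatter), so a carbonyl-linked aromatic ring and a directly attached pyridin-3-yl cannot be told apart in this comparison. The benzoyl ester keeps a clear margin, with a 4.5-fold higher number from compound 1 to compound 4 (0.65 log units; beyond the scatter), so an aromatic ring at this end does not by itself match compound 1.

No measurement on hand explains any of these differences. As far as these compounds go, it remains open what a phenyl ether would give, which would test the pyridine nitrogen, and what a secondary amine in place of the ether oxygen would give, which would test the linking atom.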